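Methylcarbamoyl to fluoro: what to expect

A few compounds are considered here, and "the series" means these few. Any claim that something is new, unique, unknown or untested is made for them only; others in the source may bear on it.

compound 1 `CCC1C(=O)N(C)c2cnc(-n3ccc4cc(C(=O)NC(C)C)ccc43)nc2N1c1ccn(C)n1`: 4350 nM
compound 2 `CCC1C(=O)N(C)c2cnc(-n3ccc4cc(C(=O)NC)ccc43)nc2N1c1ccn(C)n1`: 6330 nM
compound 3 `CC[C@@H]1C(=O)N(C)c2cnc(Nc3ccc(S(=O)(=O)NCCCO)cc3)nc2N1C1CCCC1`: 357 nM

All three were tested in a functional assay on HeLa cells (Homo sapiens) for antiproliferative activity, read by CCK-8 assay, with a stated time of 72 h; on this read-out lower numbers stand for stronger inhibition of growth and higher numbers for weaker inhibition of growth. Compound 2 sits within the scatter of compound 1, and compound 3 stands clearly lower than both. Compound 4 `CCC1C(=O)N(C)c2cnc(-n3ccc4cc(F)ccc43)nc2N1c1ccn(C)n1` keeps the core of compound 2 and changes one group: fluoro in place of methylcarbamoyl on an aromatic carbon. Among the compounds with values here, only one measured step touches this group: a 1.5-fold higher number from compound 1 to compound 2 (0.16 log units; within the scatter), with methyl in place of isopropyl on an amide-type nitrogen. That step alters the group without removing it, so it offers weak guidance and no direction. No change beyond the scatter is expected, and the estimated step is a 1.1-fold lower number from compound 2 to compound 4 (0.02 log units; within the scatter). For compound 4 the expected value is 6000 nM, with an estimated range from 1800 nM to 20000 nM.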

Compound 4, concentration for 50% growth inhibition: "not active" (no number reported)
Nothing numeric was reported for compound 4; the estimate stays without a comparison.
By their numbers in this assay, from the lowest: compound 3; then compounds 1 and 2 (each within the scatter of the next).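

Within the data shown here, compound 4 is reported in this assay only as "not active", with no number, so no step from compound 2 to compound 4 can be read. The compounds shown leave open how far replacing methylcarbamoyl with fluoro shifts growth inhibition. No supporting data bear on this result.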